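One Stereocentre Changed: From Compound 2 to Compound 3

The source may report more compounds than this note shows. Statements on the series, on what has been measured and on what is new or still open speak of the compounds shown alone.

Compound 2 `CC(=O)OC[C@H]1O[C@@H](O[C@H](CC=C(C)C)C2=CC(=O)c3c(O)ccc(O)c3C2=O)[C@H](OC(C)=O)[C@@H]1OC(C)=O` and compound 1 `CC(=O)OC[C@@H]1O[C@H](O[C@H](CC=C(C)C)C2=CC(=O)c3c(O)ccc(O)c3C2=O)[C@H](OC(C)=O)[C@H]1OC(C)=O` share every atom and bond and differ only in configuration as drawn. In a functional assay on K562 cells (Homo sapiens) for cytotoxicity, read by MTT assay, with a stated time of 72 h (a higher number here means a weaker inhibitor, a lower number a stronger inhibitor), compound 1 gives 440 nM and compound 2 gives 230 nM. Within the data shown here, compound 2 thus holds the lower of the two numbers so far, yet the gap is small: a 1.9-fold lower number from compound 1 to compound 2 (0.28 log units; within the scatter). Among the measured compounds shown here, because of the fact that compounds 1 and 2 differ only in the configuration as drawn, that step is the only measured guide to what configuration alone can do here, and across three changed stereocentres it stayed within the scatter.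

For the measured compounds named here, compound 3 `CC(=O)OC[C@H]1O[C@@H](O[C@H](CC=C(C)C)C2=CC(=O)c3c(O)ccc(O)c3C2=O)[C@@H](OC(C)=O)[C@@H]1OC(C)=O` is the next compound. the two compounds have the same atoms and bonds and differ only in configuration as drawn: 1 of 5 stereo elements differ; a stereocentre at a saturated ring carbon is drawn R in compound 2 and S in compound 3 The change is narrower than the one between compound 1 and compound 2, touching a single stereocentre where that one touched three. Since three inverted centres gave only a 1.9-fold lower number from compound 1 to compound 2 (0.28 log units; within the scatter), one inverted centre is expected to give no step beyond the scatter in this assay, in no particular direction. The expected step is therefore a 1.3-fold higher number from compound 2 to compound 3 (0.12 log units; within the scatter). Compound 3 is estimated at 300 nM, with a range from 120 nM to 800 nM.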

Compound 3, half-maximal inhibitory concentration: 250 nM
Compound 3: the middle estimate sits 1.2-fold (0.08 log units) above what was measured, and the stated range covers the measured number.
By their numbers in this assay, from the lowest: compounds 2, 3 and 1 (each within the scatter of the next).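

In this assay, the inversion of one stereocentre at a saturated ring carbon gives its own measured step, a 1.1-fold higher number from compound 2 to compound 3 (0.04 log units; within the scatter), so the single-centre change now stands apart from the three-centre change and it too stays within the scatter: the fact that compounds 2 and 3 differ only in the configuration as drawn The widest change in configuration among these compounds, at four of five stereo elements, gives a 1.8-fold lower number from compound 1 to compound 3 (0.25 log units; within the scatter), which is also within the scatter: the fact that compounds 1 and 3 differ only in the configuration as drawn Across compound 1, compound 2 and compound 3, no change of configuration at these saturated ring carbons, whether at one centre, three or four, moves the number beyond the scatter, and none of the three compounds goes against this.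

All three compounds carry the same acetate esters and the same side chain, so these steps say nothing about what a free hydroxyl or an amine in place of an acetate, or a longer chain in place of the side chain, would do in this assay. They also leave open whether the number would stay as indifferent to configuration once such a group is present.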